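The source may hold more compounds than are shown below. What is called first, only, known or untested is meant among the compounds shown, and "the series" means these compounds.

Measured so far in an ADME assay on THP-1 cells (Homo sapiens) for cytotoxicity; on this read-out lower numbers stand for higher toxicity in this test and higher numbers for lower toxicity in this test:
compound 1, `COc1ccc(NC(=O)c2c(NC(=O)c3ccccc3)sc3c2CCCCC3)cc1`, gives > 50000 nM, a limit of the assay.
compound 2, `O=C(Nc1ccccc1)c1c(NC(=O)C(F)(F)F)sc2c1CCCCC2`, gives > 50000 nM, a limit of the assay.
compound 3, `O=C(Nc1ccc(OC(F)(F)F)cc1)c1c(NC(=O)C(F)(F)F)sc2c1CCCCC2`, gives 11900 nM.

Compound 2 therefore has no measured number; its value sits at the limit of > 50000 nM in this assay, at which 2 of the 3 values shown sit. Compound 4, `COc1cccc(NC(=O)c2c(NC(=O)C(F)(F)F)sc3c2CCCCC3)c1`, differs from it by methoxy in place of hydrogen on an aromatic carbon. Among the measured compounds shown here, the only measured step that bears on this change is an at least 4.2-fold lower number from compound 2 to compound 3 (0.62 log units; beyond the scatter), where a trifluoromethoxy rather than a methoxy entered. Methoxy is not trifluoromethoxy, and compound 1, which also carries a methoxy on an aromatic carbon, gives > 50000 nM, a limit of the assay. For compound 4 a step of about an at least 1.2-fold lower number from compound 2 to compound 4 (0.09 log units; that floor lies within the scatter) is expected in this assay, with a fair chance that only a limit is reported again. The estimate for compound 4 is 40000 nM, between 15000 nM and 100000 nM.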

Compound 4, half-maximal cytotoxic concentration: 37600 nM
For compound 4 the middle estimate is 1.1-fold (0.03 log units) above the measured one, within the range that was stated.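

In this assay, among the compounds shown here, methoxy on this aromatic carbon, meta to a large group, gives compound 4 a real number, and the step (an at least 1.3-fold lower number from compound 2 to compound 4 (0.12 log units; that floor lies within the scatter)) is the first reading of this exact change. That step has only a floor, and the floor lies within the scatter, so methoxy here cannot yet be said to lower the number. Its true size stays unknown since compound 2 holds only a limit: the limit of > 50000 nM in this assay, at which 2 of the 4 values shown sit.

On these data alone, whether an amine or a carboxylic acid at this place would give a similar number remains open. So does whether methoxy elsewhere on this ring would.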